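The compounds below may be only part of what the source reports. "The series", "measured", "known", "first", "only" and "open" are said of these compounds alone.

Measured compounds:
Compound 1, `CC(=O)SCCC(CCCCC(=O)Nc1ccccc1Cl)SC(C)=O`: 15.2%
Compound 2, `CC(=O)SCCC(CCCCC(=O)Nc1cccc(Cl)c1)SC(C)=O`: 42.8%
Compound 3, `O=C(CCCCC(CCSC(=O)c1ccccc1)SC(=O)c1ccccc1)Nc1ccccc1Cl`: "not active" (no number reported)

These three compounds were tested in a functional assay on NCI-H460 cells (Homo sapiens) for inhibition, read by MTT assay, with a stated time of 24 h, tested at 100 ug/mL; a higher number here means more inhibition of growth at the concentration tested, a lower number less inhibition of growth. Compound 1 and compound 2 share a core and differ only by 3-chlorophenyl in place of 2-chlorophenyl on an amide-type nitrogen; that change gave a number 27.6 percentage points higher from compound 1 to compound 2 (beyond the scatter). Compound 3 carries a different core, and the difference between the two cores is not broken down here. Compound 3 was reported in this assay as "not active" (no number reported), so no number stands for it. Compound 4, `O=C(CCCCC(CCSC(=O)c1ccccc1)SC(=O)c1ccccc1)Nc1cccc(Cl)c1`, has not been measured; it differs from compound 3 by 3-chlorophenyl in place of 2-chlorophenyl on an amide-type nitrogen, the same change as between compound 1 and compound 2, at the same place. If the change carried over to the new core, compound 4 would be expected to sit above compound 3, though the absence of a number for compound 3 makes this uncertain. Compound 4 is estimated at 20%, within a range from 0% to 45%.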

Compound 4, percent growth inhibition at one concentration: "not active" (no number reported)
Compound 4: no number reported; no gap can be computed for the estimate.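

Compound 3 and compound 4 both stand without a number in this assay, and no new step can be read from them. As far as these compounds go, whether 3-chlorophenyl in place of 2-chlorophenyl changes growth inhibition on the core of compound 3 stays open. No measurement shown here offers an explanation.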